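Swapping the chlorophenyl amide for a chloropyridyl amide

A few compounds are considered here, and "the series" means these few. Any claim that something is new, unique, unknown or untested is made for them only; others in the source may bear on it.

Compound 1 `Cc1noc(C)c1-c1cnc(N)c(Oc2ccc(C(=O)Nc3cccc(Cl)n3)cc2)n1`: 64100 nM
Compound 2 `Cn1cc(-c2cnc(N)c(Oc3ccc(C(=O)Nc4ccccc4)cc3)n2)cn1`: 17700 nM
Compound 3 `Cn1cc(-c2cnc(N)c(Oc3ccc(C(=O)Nc4cccc(Cl)c4)cc3)n2)cn1`: 21700 nM

In a functional assay on U-87MG ATCC cells for inhibition, with U-87 MG (Homo sapiens) as the target, read by MTT assay, with a stated time of 72 h (on this read-out higher numbers stand for weaker inhibition and lower numbers for stronger inhibition), compound 3 gives the second highest of the three numbers, within the scatter of compound 2 and beyond it from compound 1. Among the compounds with values here, the only directly comparable step, a 1.2-fold higher number from compound 2 to compound 3 (0.09 log units; within the scatter), shows that adding chloro on an aromatic carbon changed little. Compound 4 `Cn1cc(-c2cnc(N)c(Oc3ccc(C(=O)Nc4cccc(Cl)n4)cc3)n2)cn1` carries 6-chloropyridin-2-yl in place of 3-chlorophenyl on an amide-type nitrogen. Within the data shown here, no measured pair isolates this change; compound 1 has the same 6-chloropyridin-2-yl amide but a different core, and its number is the highest of the three. The step is therefore expected to be a 1.6-fold higher number from compound 3 to compound 4 (0.21 log units; within the scatter), towards weaker inhibition, with wide uncertainty. Compound 4 is estimated at 35000 nM, with a range from 12000 nM to 100000 nM.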

Compound 4, half-maximal inhibitory concentration: 54800 nM
Beside the measured number, compound 4's estimate is 1.6-fold (0.19 log units) below it; low and high end bracket the measured number.
By their numbers in this assay, from the lowest: compounds 2 and 3 (each within the scatter of the next); then compounds 4 and 1 (each within the scatter of the next).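

In this assay, the ring on the amide-type nitrogen turns out to matter: 6-chloropyridin-2-yl gives weaker inhibition than 3-chlorophenyl (a 2.5-fold higher number from compound 3 to compound 4 (0.40 log units; beyond the scatter)) and than phenyl (a 3.1-fold higher number from compound 2 to compound 4 (0.49 log units; beyond the scatter)), both beyond the scatter. With this amide in place, the two groups on the aromatic carbon cannot be told apart (a 1.2-fold lower number from compound 1 to compound 4 (0.07 log units; within the scatter)), which lies within the scatter. Still open, from the compounds shown here alone, is whether an amine or a carboxylic acid in place of the chloro on that pyridine ring would recover inhibition. No evidence here explains the loss.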